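Replacing Pyridin-2-yl with Acetyl on a Ring Nitrogen

This account rests on a few compounds, and the source may have more. Where it says the series, first, only, none or still open, it means among the compounds named here.

Of the compounds shown here, three sharing one core have been tested in a functional assay on the whole organism (liver, strain NMRI) for inhibition, with Mus musculus as the target, with a stated time of 3 h, at a dose of 3 mg/kg by the oral route; on this read-out lower numbers stand for less inhibition and higher numbers for more inhibition at the one dose given (going by the name of the read-out). Compound 1 `O=[N+]([O-])c1cc(-c2nc(-c3ccccc3)no2)cc(O)c1O` gives 20.6% in this assay. Among the measured compounds shown here, compound 2 `NC(=O)c1ccc(-c2noc(-c3cc(O)c(O)c([N+](=O)[O-])c3)n2)cc1` gives 79.2%, and the single change between them, carbamoyl in place of hydrogen on an aromatic carbon, brings a number 58.6 percentage points higher from compound 1 to compound 2 (beyond the scatter). Compound 3 `O=[N+]([O-])c1cc(-c2nc(N3CCN(c4ccccn4)CC3)no2)cc(O)c1O` gives 32.2% in this assay, the second highest of the three numbers: it stands nearest to compound 1 and far beneath compound 2.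

Compound 4 `CC(=O)N1CCN(c2noc(-c3cc(O)c(O)c([N+](=O)[O-])c3)n2)CC1` has not yet been measured. Its difference from compound 3 is acetyl in place of pyridin-2-yl on an amine nitrogen in a ring. For the measured compounds named here, no measured step alters the group on an amine nitrogen in a ring; the one measured step, from compound 1 to compound 2, touches a different place and cannot point to a direction here. The estimate for compound 4 is therefore centred close to compound 3, with a wide band of uncertainty. Compound 4 is expected to give about 30% in this assay, between 5% and 60%. The expected step is a number 2.2 percentage points lower from compound 3 to compound 4 (within the scatter), which is not beyond the scatter.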

Compound 4, a percentage reported as inhibition, in the whole organism at one dose (the size of the read-out at that dose, not a potency): 68.2%
Compound 4: the middle estimate sits 38.2 percentage points below what was measured; the measured number lies above the stated range.
By their numbers in this assay, from the lowest: compound 1; then compound 3; then compound 4; then compound 2.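

Among the compounds shown here, the group on the amine nitrogen in the ring clearly matters in this assay: acetyl in place of pyridin-2-yl gives a number 36 percentage points higher from compound 3 to compound 4 (beyond the scatter), the first measured step at this position. The two groups match in hydrogen-bond donors and acceptors and neither carries a net charge, so those counts do not separate them, whereas acetyl is the smaller group and has no ring but does have a double bond outside aromatic rings. No available evidence explains why this change raises the number.

For the compounds shown here, with only this one pair, the effects of removing the aromatic ring, shortening the group and introducing the acetyl double bond cannot be separated. A methyl group or a propanoyl chain on the same nitrogen would help to show which of these differences tracks with the higher number.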